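Trifluoromethyl for Methyl on the Aryl Ketone of Compound 2

The source may hold more compounds than are shown below. What is called first, only, known or untested is meant among the compounds shown, and "the series" means these compounds.

Compound 1, `CCC(=O)c1ccc2c(c1)C(n1ccccc1=O)=CC(C)(C)O2`, gives 5.85 in a functional assay (trachea) with Rattus norvegicus as the target; a higher number here means a more potent compound, by a factor of ten per unit of this negative logarithm, a lower number a less potent compound.
Compound 2, `Cc1ccccc1C(=O)c1ccc2c(c1)C(n1ccccc1=O)=CC(C)(C)O2`, gives 6.25 in this assay.

Of these two, compound 2 stands higher, since the number rises a number 0.40 log units higher from compound 1 to compound 2 (beyond the scatter). Compound 3, `CC1(C)C=C(n2ccccc2=O)c2cc(C(=O)c3ccccc3C(F)(F)F)ccc2O1`, has not yet been measured in this assay. It differs from compound 2 in one place: trifluoromethyl in place of methyl on an aromatic carbon.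

Within the data shown here, only one measured step exists, from compound 1 to compound 2, and it swaps the whole group on the carbonyl carbon rather than a methyl for a trifluoromethyl on an aromatic carbon. Among the measured compounds shown here, no measured step therefore bears directly on this change. With nothing to point either way, a step within the scatter is expected in this assay, leaning slightly upward. Compound 3 is estimated at 6.35, within 5.75 to 6.95. The expected step from compound 2 is a number 0.10 log units higher from compound 2 to compound 3 (within the scatter).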

Compound 3, logarithm of the reciprocal of the active concentration, log(1/C): 5.78
Estimate against measurement, compound 3: 0.57 log units above, within the range that was stated.
By their numbers in this assay, from the lowest: compounds 3 and 1 (each within the scatter of the next); then compound 2.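

Among these compounds, at the aromatic carbon ortho to a large group, the result gives the first measured reading of this position: in this assay, trifluoromethyl in place of methyl is not a neutral exchange (a number 0.47 log units lower from compound 2 to compound 3 (beyond the scatter)). The rise seen with 2-methylphenyl in place of ethyl on the carbonyl carbon does not appear with 2-(trifluoromethyl)phenyl in that place (a number 0.07 log units lower from compound 1 to compound 3 (within the scatter)), so an aryl group there does not by itself bring that rise, and the group on its ortho carbon matters. Nothing available here explains the difference between methyl and trifluoromethyl at this position.

The compounds shown leave open how an unsubstituted phenyl, or a chlorine or methoxy group at this same carbon, would read in this assay. They also leave open whether a longer chain such as ethyl at this carbon would stay near compound 2 or compound 3.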